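A few compounds are considered here, and "the series" means these few. Any claim that something is new, unique, unknown or untested is made for them only; others in the source may bear on it.

Of the compounds shown here, three of one series have so far been tested in a functional assay on MCF7 cells (Homo sapiens) for cytotoxicity, read by MTT assay, with a stated time of 24 h; on this read-out higher numbers stand for weaker inhibition and lower numbers for stronger inhibition. Compound 2 `Cc1cc(-c2nc3ccccc3o2)ccc1NC(=O)CN1CCN(CCCN(C)C)CC1` gives 11300 nM in this assay. Compound 1 `Cc1cc(-c2nc3cc(Cl)ccc3o2)ccc1NC(=O)CN1CCN(CCCN(C)C)CC1` differs from it by chloro in place of hydrogen on an aromatic carbon and gives 63400 nM in this assay, which is a 5.6-fold higher number from compound 2 to compound 1 (0.75 log units; beyond the scatter). Compound 3 `CN(C)CCCN1CCN(CC(=O)Nc2ccc(-c3nc4ccccc4o3)cc2)CC1` differs from compound 2 by hydrogen in place of methyl on an aromatic carbon. In this assay compound 3 gives 23400 nM, which is a 2.1-fold higher number from compound 2 to compound 3 (0.32 log units; beyond the scatter). Compound 4 `CN(C)CCCN1CCN(CC(=O)Nc2ccc(-c3nc4cc(Cl)ccc4o3)cc2)CC1` has not been measured. It differs from compound 3 by chloro in place of hydrogen on an aromatic carbon, the same change that separates compound 2 from compound 1, so this change occurs twice among the four compounds, while the two cores differ only in the way just described for compound 3 against compound 2. Going by the values given here, a step of similar size is expected from compound 3 to compound 4, estimated at a 4.7-fold higher number from compound 3 to compound 4 (0.67 log units; beyond the scatter), because a 5.6-fold higher number from compound 2 to compound 1 (0.75 log units; beyond the scatter) is the only measured instance of this change and it rests on a single pair. Compound 4 is therefore expected to give about 110000 nM in this assay, with a likely range from 40000 nM to 300000 nM.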

Compound 4, half-maximal inhibitory concentration: 1650 nM
For compound 4 the middle estimate is 67-fold (1.82 log units) above the measured one, outside the stated range (below it).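

In this assay the chloro group in place of hydrogen gives a 14-fold lower number from compound 3 to compound 4 (1.15 log units; beyond the scatter), the opposite direction from the step it gave on the methyl-bearing core, so this change does not carry from one core to the other: the same change on two cores in this assay, a 5.6-fold higher number (0.75 log units; beyond the scatter) from compound 2 to compound 1 and a 14-fold lower number (1.15 log units; beyond the scatter) from compound 3 to compound 4, 80-fold (1.90 log units) apart, beyond the scatter of two such steps Seen from the other side, hydrogen in place of methyl gives a 38-fold lower number from compound 1 to compound 4 (1.58 log units; beyond the scatter), and this step also fails to match its earlier counterpart: the same change on two cores in this assay, a 2.1-fold higher number (0.32 log units; beyond the scatter) from compound 2 to compound 3 and a 38-fold lower number (1.58 log units; beyond the scatter) from compound 1 to compound 4, 80-fold (1.90 log units) apart, beyond the scatter of two such steps Both comparisons rest on the same four compounds, so they show that the effects of the chloro and methyl groups do not simply add in this set, but they do not show why, or whether the reversal extends beyond these compounds.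

As far as these compounds go, it remains open whether a fluoro or methoxy group in place of the chloro group would also reverse direction between these two cores. From the compounds shown here alone, it is equally open whether an ethyl group in place of the methyl group would behave like the methyl group.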